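The compounds below may be only part of what the source reports. "The series", "measured", "known", "first", "only" and "open" are said of these compounds alone.

Measured so far:
compound 1, `O=C(O)CCCO/N=c1/ccn([C@@H]2O[C@H](COP(=O)(O)OP(=O)(O)OP(=O)(O)O)[C@@H](O)[C@H]2O)c(=O)[nH]1`, 299 nM
compound 2, `O=c1[nH]/c(=N\OCCCCc2ccccc2)ccn1[C@@H]1O[C@H](COP(=O)(O)OP(=O)(O)OP(=O)(O)O)[C@@H](O)[C@H]1O`, 214 nM

In a functional assay on 1321-N1 cells for agonist activity at P2Y purinoceptor 2 (Homo sapiens), read by scintillation counting and inositol phosphate accumulation (a lower number here means that less compound is needed, a higher number that more compound is needed for the effect), compound 2 holds the lower of the two numbers, yet the step of a 1.4-fold lower number from compound 1 to compound 2 (0.15 log units; within the scatter) lies within the scatter, so nothing separates the two compounds on this assay. Compound 3 `O=c1[nH]/c(=N\OCCOc2ccccc2)ccn1[C@@H]1O[C@H](COP(=O)(O)OP(=O)(O)OP(=O)(O)O)[C@@H](O)[C@H]1O` has not yet been measured. Its difference from compound 2 is phenoxy in place of phenethyl on a saturated chain carbon, two bonds along the chain from an oxygen. Going by the values given here, only one measured step bears on this change, and it lies in the same chain, on a saturated chain carbon, three bonds along the chain from an oxygen on an unsaturated carbon: there, a 1.4-fold lower number from compound 1 to compound 2 (0.15 log units; within the scatter), which is within the scatter even though a carboxy was exchanged for a benzyl. The exchange of phenethyl for phenoxy is a smaller alteration of that chain than the one already seen, so compound 3 is expected to stay where compound 2 stands, with a step of a 1.2-fold higher number from compound 2 to compound 3 (0.07 log units; within the scatter) that does not rise beyond the scatter. Compound 3 is therefore estimated at 250 nM in this assay, with a range from 100 nM to 650 nM.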

Compound 3, half-maximal effective concentration: 3400 nM
Compound 3: the middle estimate sits 14-fold (1.13 log units) below what was measured; the measured number lies above the stated range.
By their numbers in this assay, from the lowest: compounds 2 and 1 (each within the scatter of the next); then compound 3.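

The earlier step of a 1.4-fold lower number from compound 1 to compound 2 (0.15 log units; within the scatter) had left the outer part of this chain looking free to vary in this assay, but the step of a 16-fold higher number from compound 2 to compound 3 (1.20 log units; beyond the scatter) shows that it is not: phenoxy in place of phenethyl, on a saturated chain carbon two bonds along the chain from an oxygen, is a large change here, even though both groups hold the same kind of aromatic ring. The step of an 11-fold higher number from compound 1 to compound 3 (1.06 log units; beyond the scatter) sets compound 3 apart from the carboxy-ended chain as well, so among these three compounds only compound 3 stands beyond the scatter of the others, and a terminal aromatic ring alone does not decide the number. Nothing at hand gives a reason for the size of this change.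

The compounds shown leave open whether the oxygen of the phenoxy group or the change from 4-phenylbutyl to 2-phenoxyethyl as a whole accounts for the step, since the two come together here. As far as these compounds go, how a longer chain ending in phenoxy, or an amine at the end of the chain, would stand in this assay also remains open.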